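Swapping the aromatic ring of compound 3

The compounds below may be only part of what the source reports. "The series", "measured", "known", "first", "only" and "open" are said of these compounds alone.

Compound 1 `CC1=CC[C@H](C(C)(C)NC(=S)NN)CC1`: in a functional assay on OVCAR-3 cells (Homo sapiens) for inhibition, read by sulforhodamine B assay, with a stated time of 48 h (a higher number here means a weaker inhibitor of growth, a lower number a stronger inhibitor of growth), compound 1 reaches only the limit > 100000 nM.
Compound 2 `CC1=CC[C@H](C(C)(C)NC(=S)N/N=C/c2ccc(F)cc2)CC1`: in this assay compound 2 likewise gives only the limit > 100000 nM.
Compound 3 `CC1=CC[C@H](C(C)(C)NC(=S)N/N=C/c2ccccc2Cl)CC1`: in this assay compound 3 gives 83600 nM.

Among the compounds with values here, compound 3 thus holds the only number in this assay; the other two values are limits, as the limit of > 100000 nM in this assay, at which 2 of the 3 values shown sit, records. Within the data shown here, the one measured step between neighbours, an at least 1.1-fold lower number from compound 2 to compound 3 (0.07 log units; that floor lies within the scatter), exchanges the aromatic ring at the same place and lies within the scatter. Compound 4 `CC1=CC[C@H](C(C)(C)NC(=S)N/N=C/c2ccc[nH]2)CC1` differs from compound 3 by 1H-pyrrol-2-yl in place of 2-chlorophenyl on a carbon with a double bond to nitrogen. Because an at least 1.1-fold lower number from compound 2 to compound 3 (0.07 log units; that floor lies within the scatter) stayed within the scatter, no step beyond the scatter is expected in this assay for compound 4. Compound 4 is therefore estimated at 90000 nM, between 35000 nM and 250000 nM. That estimate means a step of a 1.1-fold higher number from compound 3 to compound 4 (0.03 log units; within the scatter), expected to stay within the scatter. With the limit of > 100000 nM in this assay, at which 2 of the 3 values shown sit, a limit rather than a number remains about as likely for compound 4.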

Compound 4, concentration for total growth inhibition: > 100000 nM
Compound 4: a limit, no number; the forecaster's own chance of this, stated with the estimate: 55%; at least 1.1-fold (0.04 log units) between middle value and limit.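

In this assay, 1H-pyrrol-2-yl in place of 2-chlorophenyl on a carbon with a double bond to nitrogen gives an at least 1.1-fold higher number from compound 3 to compound 4 (0.07 log units; that floor lies within the scatter), so the change of ring size and the added hydrogen-bond donor bring no readable gain. The steps from compound 1 and from compound 2 to compound 4 cannot be read. Compound 3 remains the only compound with a number, and a third aromatic ring at this position still yields no reading beyond the scatter: the limit of > 100000 nM in this assay, at which 3 of the 4 values shown sit.

The compounds shown leave open whether a dimethylamino group or a carboxylic acid on the aromatic ring, or a plain alkyl chain in place of that ring, would give a number clearly beyond the scatter.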